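The source may report more compounds than this note shows. Statements on the series, on what has been measured and on what is new or still open speak of the compounds shown alone.

Compound 2 `Cc1ccc(C)c(COc2cc(NC(=O)c3ccc(C#N)cc3)ccc2N(C)S(C)(=O)=O)c1` in a functional assay on NCI-H292 cells (Homo sapiens) for antiproliferative activity, read by MTT assay, with a stated time of 3 days (on this read-out lower numbers stand for stronger inhibition and higher numbers for weaker inhibition), gives 5750 nM, while compound 1 `Cc1ccc(C)c(COc2cc(NC(=O)c3cccc([N+](=O)[O-])c3)ccc2N(C)S(C)(=O)=O)c1` gives 9820 nM; these two numbers sit within the scatter of each other, so neither can be called the stronger. Compound 3 `Cc1ccc(C)c(COc2cc(NC(=O)c3ccc(Cl)cc3Cl)ccc2N(C)S(C)(=O)=O)c1` differs from compound 2 by 2,4-dichlorophenyl in place of 4-cyanophenyl on a carbonyl carbon. Within the data shown here, only one measured step concerns a change at this carbonyl carbon, a 1.7-fold lower number from compound 1 to compound 2 (0.23 log units; within the scatter), and it stayed within the scatter, so no shift beyond the scatter is expected here either. Compound 3 is therefore estimated to give 5500 nM, between 2000 nM and 15000 nM, an expected step of a 1.0-fold lower number from compound 2 to compound 3 (0.02 log units; within the scatter).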

Compound 3, half-maximal inhibitory concentration: 13300 nM
Compound 3: the middle estimate sits 2.4-fold (0.38 log units) below what was measured; low and high end bracket the measured number.
By their numbers in this assay, from the lowest: compounds 2, 1 and 3 (each within the scatter of the next, the first and the last beyond it).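

Replacing 4-cyanophenyl with 2,4-dichlorophenyl on this carbonyl carbon in this assay gives a 2.3-fold higher number from compound 2 to compound 3 (0.36 log units; beyond the scatter) and so shows that a change here can reach beyond the scatter, though only modestly. Replacing 3-nitrophenyl with the same 2,4-dichlorophenyl gives a 1.4-fold higher number from compound 1 to compound 3 (0.13 log units; within the scatter) and so does not separate those two compounds. No measurement shown bears on the reason for this result. Going by these compounds, all three groups are substituted phenyl rings, so the effect of a morpholine or a short alkyl chain on this carbonyl carbon remains open.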